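The compounds below may be only part of what the source reports. "The series", "measured", "known", "first", "only" and "open" are said of these compounds alone.

Compound 1 `O=C(O)c1ccc(N2C(=O)C=CC2=O)cc1O`, compound 3 `O=C(O)c1ccc(-c2noc(CBr)n2)cc1` and compound 2 `COC(=O)c1ccc(-c2noc(CBr)n2)cc1` have been run in an ADME assay on MT2 cells (Homo sapiens) for cytotoxicity, read by XTT assay, with a stated time of 4 days; on this read-out lower numbers stand for higher toxicity in this test and higher numbers for lower toxicity in this test; compound 4 `COC(=O)c1ccc(N2C(=O)C=CC2=O)cc1O` has not. In this assay compound 1 gives only a limit of the assay, > 400000 nM. Compound 3 gives 81900 nM and compound 2 gives 32700 nM; the step of a 2.5-fold lower number from compound 3 to compound 2 (0.40 log units; beyond the scatter) goes with methyl in place of hydrogen on an oxygen next to a carbonyl group. The difference between the two cores, compound 1 against compound 3, is not broken down here. Compound 4 carries the same change on the core of compound 1: methyl in place of hydrogen on an oxygen next to a carbonyl group. The step expected from compound 1 to compound 4 is an at least 1.6-fold lower number from compound 1 to compound 4 (0.20 log units; that floor lies within the scatter), resting on the earlier step of a 2.5-fold lower number from compound 3 to compound 2 (0.40 log units; beyond the scatter) and on (the limit of > 400000 nM in this assay, at which 1 of the 3 values shown sits), which leaves the starting point of compound 1 open. Compound 4 is therefore expected near 250000 nM, between 100000 nM and 400000 nM.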

Compound 4, half-maximal cytotoxic concentration: 66200 nM
Beside the measured number, compound 4's estimate is 3.8-fold (0.58 log units) above it; the measured number lies below the stated range.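

In this assay, methyl in place of hydrogen on an oxygen next to a carbonyl group gives an at least 6.0-fold lower number from compound 1 to compound 4 (0.78 log units; beyond the scatter), and the same change also lowers the number on the other core: the same change on two cores in this assay, a 2.5-fold lower number (0.40 log units; beyond the scatter) from compound 3 to compound 2 and an at least 6.0-fold lower number (0.78 log units; beyond the scatter) from compound 1 to compound 4; the limit leaves it open whether they differ Compound 1 gives > 400000 nM, which is a limit of the assay and not a number. The direction of the change therefore carries over between these two cores, but the size of the step on the core of compound 1 is known only as a floor, and two cores say nothing about any others.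

The compounds shown leave open how an ethyl ester or an amide in place of the methyl ester would read on either core. They also leave open how much of the difference between compound 1 and compound 3 belongs to the cores themselves.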